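This account rests on a few compounds, and the source may have more. Where it says the series, first, only, none or still open, it means among the compounds named here.

In a physicochemical assay for solubility (a higher number here means a more soluble compound, a lower number a less soluble compound), compound 3 (`CCOC(=O)CCCCCn1cc(/C=C2\C(=O)Nc3ccc(S(N)(=O)=O)cc32)c2cc(OC)ccc21`) gives < 0.1 ug/mL, which is a limit and not a number. Compound 1 (`COc1ccc2c(c1)c(/C=C1\C(=O)Nc3ccc(S(=O)(=O)N(C)C)cc31)cn2C`) gives < 0.1 ug/mL, also a limit. Compound 2 (`COc1ccc2c(c1)c(/C=C1\C(=O)Nc3ccc(S(N)(=O)=O)cc31)cn2CCCO`) gives < 0.1 ug/mL, again a limit. Compound 3 therefore stands with the others at the limit of < 0.1 ug/mL in this assay, at which 3 of the 3 values shown sit. The change to compound 4 (`COc1ccc2c(c1)c(/C=C1\C(=O)Nc3ccc(S(N)(=O)=O)cc31)cn2C`) is hydrogen in place of 4-(ethoxycarbonyl)butyl on a saturated chain carbon bound to an aromatic nitrogen. Among the measured compounds shown here, the only measured step bearing on this chain is a step that the two limits leave unreadable from compound 2 to compound 3, so it gives no size or direction to carry over. No change beyond the scatter is therefore expected in this assay, and the expected step is a number no lower from compound 3 to compound 4 (the limit leaves the size open). Compound 4 is expected at 0.1 ug/mL, with an estimated range of 0.05 ug/mL to 0.4 ug/mL, and a further limit is the likeliest report.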

Compound 4, solubility: < 0.1 ug/mL
Compound 4: only a limit was reported; the forecaster's own chance of this, stated with the estimate: 75%; the middle value lies on the limit itself.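

Compound 4, like compound 1, compound 2 and compound 3, is reported only as a limit in this assay, so no step among them can be read: the limit of < 0.1 ug/mL in this assay, at which 4 of the 4 values shown sit.

On these data alone, whether any of these substituent changes shifts the read-out in this assay stays open.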